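Thiophenylmethyl urea at the carbonyl of compound 2

The source may hold more compounds than are shown below. What is called first, only, known or untested is meant among the compounds shown, and "the series" means these compounds.

Two ureas sharing one core have been measured in an assay on CHO cells for displacement of a labelled ligand from histamine receptor H3 (Macaca mulatta), read by scintillation counting, with a stated time of 1 h; on this read-out higher numbers stand for weaker inhibition and lower numbers for stronger inhibition. Compound 1 `CC1CCCN1C1CCN(c2ccc(NC(=O)NC3CCCCC3)cc2)C1` carries a cyclohexylamino group on the carbonyl carbon and gives 4.1 nM. Among the compounds with values here, compound 2 `CC(=O)N(C)C1CCN(C(=O)Nc2ccc(N3CCC(N4CCCC4C)C3)cc2)C1` carries a 3-(acetyl(methyl)amino)pyrrolidin-1-yl group in that place and gives 35.5 nM, the highest of the two numbers; the only step available, an 8.7-fold higher number from compound 1 to compound 2 (0.94 log units; beyond the scatter), separates it from compound 1.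

Compound 3 `CC1CCCN1C1CCN(c2ccc(NC(=O)NCc3cccs3)cc2)C1` is the next candidate. Its change from compound 2 is ((thiophen-2-yl)methyl)amino in place of 3-(acetyl(methyl)amino)pyrrolidin-1-yl on a carbonyl carbon. Within the data shown here, the one measured step that bears on it runs the other way: an 8.7-fold higher number from compound 1 to compound 2 (0.94 log units; beyond the scatter) accompanied the loss of the hydrogen-bond donor on the urea nitrogen. Compound 3 restores such a donor, as counted above, so a step downward in this assay, of a size comparable to that earlier step, is expected, putting compound 3 close to compound 1. The estimate for compound 3 is therefore 6 nM, with a likely range from 2 nM to 20 nM, corresponding to an expected step of a 5.9-fold lower number from compound 2 to compound 3 (0.77 log units; beyond the scatter).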

Compound 3, inhibition constant: 1.9 nM
Compound 3: middle estimate off by 3.2-fold (0.50 log units), on the high side; measured number below the stated range.
By their numbers in this assay, from the lowest: compound 3; then compound 1; then compound 2.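

At the carbonyl carbon of the urea, this assay shows that the saturated cyclohexyl ring on the amide-type nitrogen is not needed for a low number, as an aromatic five-membered ring with sulfur on a one-carbon link goes further, with a 2.2-fold lower number from compound 1 to compound 3 (0.33 log units; beyond the scatter). Within the data shown here, the same group gives a 19-fold lower number from compound 2 to compound 3 (1.27 log units; beyond the scatter), a larger step than the one that first separated compound 1 and compound 2, so the position now shows a wider spread and both groups attached through an amino nitrogen sit on the low side of the 3-(acetyl(methyl)amino)pyrrolidin-1-yl group, with none of these three compounds going against that. Nothing in hand gives a reason for either step.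

The compounds shown leave open whether the sulfur-containing ring or the one-carbon link accounts for the low number of compound 3, and a benzyl group or a 2-(thiophen-2-yl)ethyl chain on the same nitrogen would separate the two. They also leave open which part of the 3-(acetyl(methyl)amino)pyrrolidin-1-yl group goes with the high number of compound 2, since its ring, its acetyl group and the missing amide hydrogen all change together, and a plain pyrrolidin-1-yl group would take the acetyl part away.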